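Oxazole ketone series: acyl substituent swap at the ring carbon

This account rests on a few compounds, and the source may have more. Where it says the series, first, only, none or still open, it means among the compounds named here.

Three compounds share one core. Compound 1 `CN(C)C(=O)c1cnc(C(=O)CCc2ccc(-c3ccccc3)cc2)o1` gives 3 nM in an assay for inhibition of Fatty-acid amide hydrolase 1 (Rattus norvegicus); on this read-out lower numbers stand for stronger inhibition and higher numbers for weaker inhibition. Compound 2 `CN(C)C(=O)c1cnc(C(=O)CCc2ccc(COc3ccccc3)cc2)o1` gives 6.7 nM in this assay, and compound 3 `O=C(CCc1ccc(-c2ccccc2)cc1)c1ncc(C(=O)C(F)(F)F)o1` gives 8 nM in this assay. Among these, compound 2 holds the second highest number: its step from compound 1 is a 2.2-fold higher number from compound 1 to compound 2 (0.35 log units; beyond the scatter), while its value and that of compound 3 lie within the scatter of each other.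

Compound 4 `O=C(O)c1ccc(-c2cnc(C(=O)CCc3ccc(COc4ccccc4)cc3)o2)nc1` is not yet measured. It differs from compound 2 in one place: 5-carboxypyridin-2-yl in place of dimethylcarbamoyl on an aromatic carbon. The measured step that touches the same carbon is a 2.7-fold higher number from compound 1 to compound 3 (0.43 log units; beyond the scatter), a modest rise when the dimethylcarbamoyl leaves; the other step, a 2.2-fold higher number from compound 1 to compound 2 (0.35 log units; beyond the scatter), concerns a different part and does not bear on it directly. Both measured changes at either end moved the number only modestly, so a change of similar size is expected here, likely toward a lower number given the much larger group entering, though this is uncertain. Compound 4 is expected to give 4 nM, between 0.8 nM and 20 nM, a step of a 1.7-fold lower number from compound 2 to compound 4 (0.22 log units; within the scatter).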

Compound 4, inhibition constant: 4.6 nM
Compound 4: middle estimate off by 1.2-fold (0.06 log units), on the low side, and the stated range covers the measured number.
By their numbers in this assay, from the lowest: compounds 1, 4, 2 and 3 (each within the scatter of the next, the first and the last beyond it).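

In this assay, 5-carboxypyridin-2-yl in place of dimethylcarbamoyl on the aromatic carbon next to the ring oxygen gives a 1.5-fold lower number from compound 2 to compound 4 (0.16 log units; within the scatter), so the larger group leaves the read-out within the scatter. Until now this carbon had carried only carbonyl-linked groups, whereas compound 4 shows that, with the phenoxymethyl tail, a six-membered aromatic ring bearing a carboxylic acid can sit directly on it with the number still in the low nanomolar range. Nothing available explains this tolerance.

From the compounds shown here alone, what the carboxylic acid contributes apart from the ring remains open, and a plain pyridin-2-yl group or a methyl ester at this carbon would separate the two. Also open, going by these compounds, is whether the same exchange holds with the phenyl tail of compound 1.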